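A few compounds are considered here, and "the series" means these few. Any claim that something is new, unique, unknown or untested is made for them only; others in the source may bear on it.

Measured in a functional assay on HeLa cells (Homo sapiens) for inhibition, read by MTT assay, with a stated time of 24 h; on this read-out lower numbers stand for stronger inhibition and higher numbers for weaker inhibition:
Compound 1 `CCOC(=O)C1=Cc2ccccc2OC1(OCc1cn(CC(=O)Nc2cccc(Cl)c2)nn1)C(F)(F)F`: 12300 nM
Compound 2 `CCOC(=O)C1=Cc2ccccc2OC1(OCc1cn(CC(=O)NC2CCCCC2)nn1)C(F)(F)F`: 11400 nM
Compound 3 `CCCCCCCCn1cc(COC2(C(F)(F)F)Oc3ccccc3C=C2C(=O)OCC)nn1`: > 150000 nM, which is a limit of the assay and not a number.

Compound 3 stands at the weak end of what has been measured, sitting at the limit of > 150000 nM in this assay, at which 1 of the 3 values shown sits. For the measured compounds named here, compounds 1 and 2 are the only compounds with numbers, and a 1.1-fold lower number from compound 1 to compound 2 (0.03 log units; within the scatter) shows that the amide substituent on that arm hardly matters.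

Compound 4 `CCOC(=O)C1=Cc2ccccc2OC1(OCc1cn(-c2ccc(F)c([N+](=O)[O-])c2)nn1)C(F)(F)F` changes the substituent on the ring nitrogen: 4-fluoro-3-nitrophenyl in place of octyl on an aromatic nitrogen. The measured steps that touch this position are an at least 12-fold higher number from compound 1 to compound 3 (1.08 log units; beyond the scatter) and an at least 13-fold higher number from compound 2 to compound 3 (1.11 log units; beyond the scatter), both large losses when the carbamoyl-bearing arm was exchanged for a plain chain. Going by the values given here, compound 4 does not restore that arm but places an aromatic group directly on the ring nitrogen, a change no measured step covers. Some recovery from the limit is expected, with wide uncertainty; the step expected in this assay is an at least 3.7-fold lower number from compound 3 to compound 4 (0.57 log units; beyond the scatter). Compound 4 is estimated at 40000 nM, within 10000 nM to 160000 nM.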

Compound 4, half-maximal inhibitory concentration: 15600 nM
Beside the measured number, compound 4's estimate is 2.6-fold (0.41 log units) above it; measured number inside the range.
By their numbers in this assay, from the lowest: compounds 2, 1 and 4 (each within the scatter of the next). At a limit, above all of these: compound 3.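

In this assay, an at least 9.6-fold lower number from compound 3 to compound 4 (0.98 log units; beyond the scatter), which shows that an aromatic group set directly on the ring nitrogen moves the series off the plain-chain result without any amide-bearing arm. Compound 3 holds a limit of the assay and not a number, and the step therefore gives only a bound: the limit of > 150000 nM in this assay, at which 1 of the 4 values shown sits. Both a 1.4-fold higher number from compound 2 to compound 4 (0.14 log units; within the scatter) and a 1.3-fold higher number from compound 1 to compound 4 (0.10 log units; within the scatter) place 4-fluoro-3-nitrophenyl level with the two carbamoyl-bearing arms, so among these compounds the amide is not needed at this position for values of this order.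

Still open, as far as these compounds go, is whether the phenyl ring alone carries this result or whether its fluoro and nitro substituents contribute. Also open, from the compounds shown here alone, is how an unsubstituted phenyl, a shorter alkyl chain or an amine-bearing chain on the same ring nitrogen would read out.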